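Adding hydroxy to compound 2: expected effect on growth inhibition

The source may report more compounds than this note shows. Statements on the series, on what has been measured and on what is new or still open speak of the compounds shown alone.

Of the compounds shown here, two have numbers so far. In a functional assay on cells (Cancer cell lines, Homo sapiens) for inhibition, with a stated time of 48 h (a lower number here means a stronger inhibitor of growth, a higher number a weaker inhibitor of growth), compound 1 (`COc1cc2c(/C=C3/C(=O)Nc4ccc(N(C)C)cc43)c(Cl)n(C)c2cc1C`) gives 20400 nM and compound 2 (`COc1cc2c(/C=C3/C(=O)N(C)c4ccccc43)c[nH]c2cc1C`) gives 4170 nM as the lower of the two numbers, a gap beyond the scatter. These two compounds differ in more than one place, so their gap cannot be assigned to any single group.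

Compound 3 (`COc1cc2c(/C=C3/C(=O)N(C)c4ccc(O)cc43)c[nH]c2cc1C`) departs from compound 2 by hydroxy in place of hydrogen on an aromatic carbon with hydroxy in place of hydrogen on an aromatic carbon. Among the compounds with values here, no measured pair shows this change, so the expectation starts from compound 2 at 4170 nM and has nothing else to lean on. In this assay the expected change is a 1.4-fold lower number from compound 2 to compound 3 (0.14 log units; within the scatter) as a small move toward stronger inhibition of growth, not beyond the scatter. For compound 3 the estimate is 3000 nM with an expected range from 1000 nM to 9000 nM for repeated measurements.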

Compound 3, concentration for 50% growth inhibition: 3550 nM
For compound 3 the middle estimate is 1.2-fold (0.07 log units) below the measured one; low and high end bracket the measured number.
By their numbers in this assay, from the lowest: compounds 3 and 2 (each within the scatter of the next); then compound 1.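

In this assay, within the data shown here, hydroxy in place of hydrogen on an aromatic carbon gives a 1.2-fold lower number from compound 2 to compound 3 (0.07 log units; within the scatter) and is the first change that can be read in one place. At this carbon, meta to a fused ring and para to a fused ring, hydroxy brings in a hydrogen-bond donor and a hydrogen-bond acceptor without a shift beyond the scatter, so the hydrogen here can be replaced without a clear change in growth inhibition. Nothing available explains this outcome.

Still open, from the compounds shown here alone, is whether another group on this same aromatic carbon, such as methoxy, an amine or a carboxylic acid, would move the number beyond the scatter. The gap between compound 1 at 20400 nM and compound 2 at 4170 nM also remains unassigned to any one of the places in which they differ.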